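A few compounds are considered here, and "the series" means these few. Any claim that something is new, unique, unknown or untested is made for them only; others in the source may bear on it.

Compound 1 `CSc1ccc(-c2nc3c(Sc4ccccc4)ncnc3n2C)cc1`, compound 2 `CSc1ccc(-c2nc3c(Sc4ccc(F)cc4)ncnc3n2C)cc1` and compound 3 `c1ccc(Cn2cnc3c(Sc4ccccc4)ncnc32)cc1` were tested in an assay on isolated protein for inhibition of Ca2+/calmodulin-dependent protein kinase II (CaM kinase II) (Rattus norvegicus), tested at 30 uM; on this read-out higher numbers stand for more inhibition at the one concentration tested (going by the name of the read-out) and lower numbers for less inhibition. Compound 1 gives 0%, compound 2 gives 7% and compound 3 gives 3%. Compounds 1 and 2 differ in one place, (fluoro in place of hydrogen on an aromatic carbon), and in this assay the step is a number 7 percentage points higher from compound 1 to compound 2 (within the scatter). The difference between the core of compound 1 and the core of compound 3 is not broken down here; their two values lie within the scatter of each other, as do those of compound 3 and compound 2. Compound 4 `Fc1ccc(Cn2cnc3c(Sc4ccccc4)ncnc32)cc1` has not yet been measured in this assay. It differs from compound 3 by fluoro in place of hydrogen on an aromatic carbon, the same change as that between compound 1 and compound 2, at a place described in the same words. Compound 4 is therefore expected to show a step of a number 5 percentage points higher from compound 3 to compound 4 (within the scatter) in this assay, because the same change earlier gave a number 7 percentage points higher from compound 1 to compound 2 (within the scatter). Compound 4 is estimated at 8%, in a range from -5% to 20%.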

Compound 4, a percentage reported as inhibition, at one concentration (the size of the read-out at that concentration, not a potency): 0%
Compound 4: the middle estimate sits 8 percentage points above what was measured; the range from low to high includes it.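

Carried to the second core, the change gives a number 3 percentage points lower from compound 3 to compound 4 (within the scatter) in this assay. Set beside the earlier step, the two readings do not come apart: the same change on two cores in this assay, a number 7 percentage points higher (within the scatter) from compound 1 to compound 2 and a number 3 percentage points lower (within the scatter) from compound 3 to compound 4, 10 percentage points apart, within the scatter of two such steps. Among these compounds, this shows that on both cores the change leaves the read-out within the scatter, but it gives no direction for the step and does not show how the change would carry over to a compound with clear inhibition.

The compounds shown leave open whether an amine or a carboxylic acid in place of the fluoro would raise the read-out beyond the scatter. They also leave open whether a longer chain in place of the benzyl would do so.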